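This account rests on a few compounds, and the source may have more. Where it says the series, first, only, none or still open, it means among the compounds named here.

Measured so far:
- compound 1, `O=C(CO[N+](=O)[O-])Nc1ccc(C(=O)/C=C/c2ccco2)cc1`: 39%
- compound 2, `COc1ccc(/C=C/C(=O)c2ccc(NC(=O)COc3ccc(C(C)=O)cc3)cc2)cc1`: 30%

Of the compounds shown here, two have been tested in a functional assay on the whole organism (strain albino) for inhibition, with Rattus norvegicus as the target, read by paw edema, with stated times of 30 min and 5 h, at a dose of 100 mg/kg by the oral route; on this read-out lower numbers stand for less inhibition and higher numbers for more inhibition at the one dose given (going by the name of the read-out). Compound 1 gives 39% in this assay, and compound 2 gives 30%. Of the two numbers, that of compound 2 is the lower, but the gap to compound 1 lies within the usual scatter, so the two results cannot be told apart. Among the compounds with values here, no step between measured compounds that differ in one place is available.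

Compound 3, `CC(=O)c1ccc(OCC(=O)Nc2ccc(C(=O)/C=C/c3ccco3)cc2)cc1`, has not yet been measured in this assay. It differs from compound 2 in one place: furan-2-yl in place of 4-methoxyphenyl on a double-bonded chain carbon bound to a double-bonded chain carbon. Compound 3 thus carries the furan-2-yl end that compound 1 also carries, and the acetylphenoxy amide part that compound 2 carries.

With compound 1 at 39% and compound 2 at 30% indistinguishable, the step from compound 2 to compound 3 is expected to be small, rising if anything, and not beyond the scatter: a number 5 percentage points higher from compound 2 to compound 3 (within the scatter). Compound 3 is therefore estimated to give 35% in this assay, with a range from 22% to 48%.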

Compound 3, a percentage reported as inhibition, in the whole organism at one dose (the size of the read-out at that dose, not a potency): 36%
The estimate for compound 3 lay 1 percentage points below the measured number; measured number inside the range.
By their numbers in this assay, from the lowest: compounds 2, 3 and 1 (each within the scatter of the next).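

In this assay, furan-2-yl in place of 4-methoxyphenyl on a double-bonded chain carbon bound to a double-bonded chain carbon gives a number 6 percentage points higher from compound 2 to compound 3 (within the scatter), so at this position a five-membered aromatic ring with 1 hetero atom and a six-membered aromatic ring of carbon only cannot be told apart. The second change, 4-acetylphenyl in place of nitro on an oxygen on a saturated carbon, gives a number 3 percentage points lower from compound 1 to compound 3 (within the scatter), so this exchange at the other end of the molecule cannot be told apart from no change either. Nothing at hand gives a measured reason for either result, and the size of the two steps cannot be explained from these compounds alone.

On these data alone, whether any group at these two places can move the number beyond the scatter remains open, since every comparison here stays within it. Also open, as far as these compounds go, is what a phenyl ring carrying an amine or a carboxylic acid would give on the double-bonded chain carbon, and what a longer chain would give on the oxygen on a saturated carbon in place of 4-acetylphenyl or nitro.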